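Fluoro for hydrogen: cytotoxicity notes on the series

A few compounds are considered here, and "the series" means these few. Any claim that something is new, unique, unknown or untested is made for them only; others in the source may bear on it.

compound 1, `O=C(NCCO)c1c(NO)cc(-c2ccc(F)cc2)oc1=O`: in an ADME assay on Huh-7 cells (Homo sapiens) for cytotoxicity, read by a luciferase reporter and WST assay, with a stated time of 3 days (a lower number here means that less compound is tolerated, a higher number that more compound is tolerated), compound 1 gives > 20000 nM, a limit of the assay
compound 2, `COC(=O)CNC(=O)c1c(NO)cc(-c2ccccc2)oc1=O`: in this assay compound 2 gives > 20000 nM, also a limit

Compound 2 thus stands only at a limit in this assay, and the other value shown is a limit too, as the limit of > 20000 nM in this assay, at which 2 of the 2 values shown sit, records. Compound 3, `COC(=O)CNC(=O)c1c(NO)cc(-c2ccc(F)cc2)oc1=O`, differs from compound 2 by fluoro in place of hydrogen on an aromatic carbon. Among the measured compounds shown here, no step between measured compounds is given, so no shift beyond the usual scatter is expected. Compound 3 is expected at 30000 nM, within 15000 nM to 80000 nM, most likely again reported only as a limit. The expected step is a step that the limit leaves unreadable from compound 2 to compound 3, none beyond the scatter.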

Compound 3, half-maximal cytotoxic concentration: > 20000 nM
Compound 3: a limit, no number; the forecaster's own chance of this, stated with the estimate: 85%; the middle value does not contradict the limit.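

Among the compounds shown here, no step to compound 3 can be read, from either compound 1 or compound 2, because all three compounds sit at a limit: the limit of > 20000 nM in this assay, at which 3 of the 3 values shown sit. From the compounds shown here alone, still open: each compound's actual half-maximal cytotoxic concentration, and whether phenyl to 4-fluorophenyl changes it.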